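The source may hold more compounds than are shown below. What is called first, only, known or untested is meant among the compounds shown, and "the series" means these compounds.

Measured compounds in a functional assay on MCF7 cells (Homo sapiens) for antiproliferative activity, read by sulforhodamine B assay, with a stated time of 48 h; a lower number here means a stronger inhibitor, a higher number a weaker inhibitor:
compound 1 `CC(=O)Nc1ccc(S(=O)(=O)Oc2ccccc2I)cc1` — 27000 nM
compound 2 `CCC(=O)Nc1ccc(S(=O)(=O)Oc2ccccc2I)cc1` — 8100 nM
compound 3 `CC(C)C(=O)Nc1ccc(S(=O)(=O)Oc2ccccc2C(C)C)cc1` — 8600 nM

Compound 3 stands second highest of the three numbers in this assay. Its nearest neighbour is compound 2, whose number sits within the scatter of compound 3; the furthest is compound 1, whose number is beyond the scatter higher. Among the compounds with values here, the only step between compounds differing in one place is a 3.3-fold lower number from compound 1 to compound 2 (0.52 log units; beyond the scatter), which concerns the amide chain and not the sulfonate aryl ring.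

Compound 4 `CC(C)C(=O)Nc1ccc(S(=O)(=O)Oc2ccccc2I)cc1` differs from compound 3 by iodo in place of isopropyl on an aromatic carbon. Within the data shown here, no measured step bears on this change directly. Compounds 2 and 3 differ at both the amide chain and this aromatic position, and their values lie within the scatter of each other, which gives no sign of a large effect from either alteration. The expectation for compound 4 in this assay is therefore a step of a 1.1-fold lower number from compound 3 to compound 4 (0.03 log units; within the scatter), not beyond the scatter. Compound 4 is estimated at 8000 nM, within 3000 nM to 22000 nM.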

Compound 4, half-maximal inhibitory concentration: 8100 nM
Compound 4: middle estimate off by 1.0-fold (0.01 log units), on the low side, within the range that was stated.
By their numbers in this assay, from the lowest: compounds 2, 4 and 3 (each within the scatter of the next); then compound 1.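

With isopropyl on the carbonyl carbon held fixed, iodo in place of isopropyl on the aromatic carbon gives a 1.1-fold lower number from compound 3 to compound 4 (0.03 log units; within the scatter) in this assay, so at this position the single iodine and the three-carbon group cannot be told apart by this read-out. With iodo held fixed, isopropyl in place of methyl on the carbonyl carbon gives a 3.3-fold lower number from compound 1 to compound 4 (0.52 log units; beyond the scatter), whereas the further methyl on the chain gives no change at the digits printed from compound 2 to compound 4 (within the scatter), so among these compounds the step beyond the scatter comes with the propanoyl chain of compound 2 and is not extended in compound 4. No measurement on hand offers a cause for these readings.

Going by these compounds, whether this position tolerates other groups, such as a methoxy or a chlorine, remains open. Also open, on these data alone, is how a longer chain, a cyclopropyl or a terminal amine on the carbonyl side reads in this assay against compound 2 and compound 4.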